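Compound 1 and a Carboxy-Methoxyphenyl Variant in Binding

The source may report more compounds than this note shows. Statements on the series, on what has been measured and on what is new or still open speak of the compounds shown alone.

Measured compounds:
Compound 1, `O=C(O)Cc1ccc(C=C2CCN(C(=O)C(C3CCCCC3)C3CCCCC3)CC2)cc1`, gives 6%.
Compound 2, `O=C(O)c1ccc(C=C2CCN(C(=O)CC(c3ccccc3)c3ccccc3)CC2)cc1`, gives 8%.

Of the compounds shown here, two have been tested in an assay for inhibition of 3-oxo-5-alpha-steroid 4-dehydrogenase 1 (Homo sapiens), tested at 10 uM; a higher number here means more inhibition at the concentration tested (going by the name of the read-out), a lower number less inhibition. Compound 1 gives 6%, and compound 2 gives 8%. Both numbers are low, and the gap between them lies within the usual scatter of repeated measurements, so compound 1 cannot be set apart from compound 2 on these numbers; it simply stands among two weak results.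

Compound 3, `COc1cc(C(=O)O)ccc1C=C1CCN(C(=O)C(C2CCCCC2)C2CCCCC2)CC1`, has not yet been measured in this assay . It differs from compound 1 in one place: 4-carboxy-2-methoxyphenyl in place of 4-(carboxymethyl)phenyl on a double-bonded chain carbon bound to a double-bonded ring carbon. Among the measured compounds shown here, no step between two measured compounds is available to show what such a change does here.

For the measured compounds named here, for compound 3, the step from compound 1 is expected to be small, a number 6 percentage points higher from compound 1 to compound 3 (within the scatter), and not clearly beyond the scatter in either direction, because compound 1 gives 6% and nothing measured so far points to a large rise. Compound 3 is estimated at 12%, in the range 0% to 35%.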

Compound 3, a percentage reported as inhibition, at one concentration (the size of the read-out at that concentration, not a potency): 5%
Estimate against measurement, compound 3: 7 percentage points above; low and high end bracket the measured number.
By their numbers in this assay, from the lowest: compounds 3, 1 and 2 (each within the scatter of the next).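

Putting 4-carboxy-2-methoxyphenyl in place of 4-(carboxymethyl)phenyl on a double-bonded chain carbon bound to a double-bonded ring carbon gives, in this assay, a number 1 percentage points lower from compound 1 to compound 3 (within the scatter). Among the compounds shown here, this is the first step that can be read at this position, and it shows that this exchange, which adds one oxygen and one hydrogen-bond acceptor by count and keeps the single hydrogen-bond donor, does not lift the read-out clear of repeat-measurement scatter at the concentration tested. No measurement at hand offers an explanation for this result.

The exchange turns carboxymethyl into carboxy and adds a methoxy in a single step, so the compounds shown cannot tell whether each change alone would leave the number as flat or whether two separate effects happen to cancel. Also open, going by these compounds, is whether a group of another kind at this position, such as an amine or a primary amide in place of the carboxylic acid, would move the number beyond the scatter on the core of compound 1.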